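Tertiary alcohols and ethers: allyl to 4-methylbenzyl

The compounds below may be only part of what the source reports. "The series", "measured", "known", "first", "only" and "open" are said of these compounds alone.

Measured so far in a functional assay on MDA-MB-231 cells (Homo sapiens) for inhibition, read by sulforhodamine B assay, with a stated time of 48 h; a lower number here means a stronger inhibitor, a higher number a weaker inhibitor:
- compound 1 `COc1ccc(C(O)(Cc2ccc(C)cc2)c2cccc3ccccc23)c(OC)c1OC`: the result is a limit, > 20000 nM
- compound 2 `C=CCC(O)(c1ccc(OC)c(OC)c1OC)c1cccc2ccccc12`: the result is a limit, > 20000 nM
- compound 3 `C=CCOC(c1ccc(OC)c(OC)c1OC)c1cccc2ccccc12`: the result is a limit, > 20000 nM

None of the three gives a number in this assay; every value shown is a limit, and the limit of > 20000 nM in this assay, at which 3 of the 3 values shown sit, is the whole of the evidence. The step from compound 2 to compound 1 is a step that the two limits leave unreadable from compound 2 to compound 1; its size cannot be read from two limits. The change behind it is 4-methylphenyl in place of vinyl on a saturated chain carbon, two bonds along the chain from two aromatic carbons and an oxygen on a saturated carbon.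

Compound 3 and compound 2 carry the same atoms joined differently; the difference between the two cores is not broken down here. Compound 3 stands at a limit, like the two others.

The unmeasured compound 4 `COc1ccc(C(OCc2ccc(C)cc2)c2cccc3ccccc23)c(OC)c1OC` is reached from compound 3 by 4-methylphenyl in place of vinyl on a saturated chain carbon bound to an oxygen on a saturated carbon. For the measured compounds named here, this is the same kind of change as the one from compound 2 to compound 1, but not the same: there the place is a saturated chain carbon two bonds along the chain from two aromatic carbons and an oxygen on a saturated carbon, here it is a saturated chain carbon bound to an oxygen on a saturated carbon.

The step expected from compound 3 to compound 4 in this assay is a step that the limit leaves unreadable from compound 3 to compound 4, resting on nothing more than the fact that compound 3 sits at > 20000 nM and that the same kind of change left compound 1 at a limit too. For compound 4 the expected value is 25000 nM, with a range from 8000 nM to 60000 nM, most likely again only a limit.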

Compound 4, half-maximal inhibitory concentration: > 20000 nM
Compound 4: a limit, no number; the forecaster's own chance of this, stated with the estimate: 80%; the middle value is on the limit's open side.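

In this assay compound 4 gives > 20000 nM, a limit and not a number. No new step can be read, as the size of the change from compound 3 to compound 4 cannot be taken from two limits: the limit of > 20000 nM in this assay, at which 4 of the 4 values shown sit.

The compounds shown leave open whether any compound of this kind gives a number in this assay, and what size the change from allyl to 4-methylbenzyl has in either pair.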